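This account rests on a few compounds, and the source may have more. Where it says the series, first, only, none or still open, it means among the compounds named here.

Compound 2 `O=c1cc(-n2cc(COc3ccccc3O)nn2)c2cc(Br)ccc2o1` shares its core with compound 1 `O=c1cc(-n2cc(CSc3ccccc3)nn2)c2cc(Br)ccc2o1`, and in a functional assay on SW480 cells (Homo sapiens) for antiproliferative activity, read by MTT assay, with a stated time of 48 h (a higher number here means a weaker inhibitor, a lower number a stronger inhibitor), compound 1 gives 15400 nM. In this assay compound 2 gives 19100 nM, the higher of the two numbers at hand, though the gap to compound 1 is small: a 1.2-fold higher number from compound 1 to compound 2 (0.09 log units; within the scatter). Compound 3 `O=c1cc(-n2cc(COc3ccc(F)cc3)nn2)c2cc(Br)ccc2o1` differs from compound 2 in one place, (4-fluorophenyl in place of 2-hydroxyphenyl on an oxygen on a saturated carbon). For the measured compounds named here, the only measured step bears on it loosely, since it swapped the group on the saturated chain carbon rather than the substituent on the aromatic ring, and that step stayed within the scatter. With nothing else to go on, the expected step for compound 3 is small, a 1.1-fold lower number from compound 2 to compound 3 (0.05 log units; within the scatter), in no clear direction. Compound 3 is therefore estimated at 17000 nM in this assay, with a range from 7000 nM to 45000 nM.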

Compound 3, half-maximal inhibitory concentration: 1770 nM
The estimate for compound 3 lay 9.6-fold (0.98 log units) above the measured number; the measured number lies below the stated range.
By their numbers in this assay, from the lowest: compound 3; then compounds 1 and 2 (each within the scatter of the next).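

The group on this oxygen on a saturated carbon matters far more in this assay than compounds 1 and 2 suggested, since their numbers lay within the scatter of each other. Placing 4-fluorophenyl in place of 2-hydroxyphenyl gives an 11-fold lower number from compound 2 to compound 3 (1.03 log units; beyond the scatter) and is a large step, while 4-fluorophenoxy in place of phenylsulfanyl gives an 8.7-fold lower number from compound 1 to compound 3 (0.94 log units; beyond the scatter) and is a modest one, so compound 3 stands apart from both. Nothing available accounts for the size of these steps.

The step to compound 3 removes the hydroxy group and brings in the fluorine together, so the share of each remains unresolved. Going by these compounds, it also remains open what an unsubstituted phenyl, a 4-chlorophenyl or a 4-aminophenyl would give on the same oxygen.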